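Azetidine carboxamide benzyl ethers: moving the amide

The source may report more compounds than this note shows. Statements on the series, on what has been measured and on what is new or still open speak of the compounds shown alone.

Measured so far:
compound 1 `NC(=O)[C@@H]1CCN1Cc1ccc(OCc2cccc(F)c2)cc1Cl`: 35 nM
compound 2 `NC(=O)C1CN(Cc2ccc(OCc3cccc(F)c3)cc2)C1`: 1420 nM

In an assay on Sf9 cells for inhibition of Amine oxidase [flavin-containing] B (Homo sapiens), with stated times of 15 min and 60 min (a higher number here means a weaker inhibitor, a lower number a stronger inhibitor), compound 1 gives 35 nM, while compound 2 gives 1420 nM, the higher of the two numbers and beyond the scatter from compound 1. Compound 3 `NC(=O)[C@@H]1CCN1Cc1ccc(OCc2cccc(F)c2)cc1` is not yet measured; it differs from compound 2 by 2-carbamoylazetidin-1-yl in place of 3-carbamoylazetidin-1-yl on a saturated chain carbon bound to an aromatic carbon, and it also lacks the chlorine present in compound 1. The carboxamide position of compound 3 matches that of compound 1, so a lower number than compound 2 is expected, with the size of the step from compound 2 to compound 3 estimated at a 9.5-fold lower number from compound 2 to compound 3 (0.98 log units; beyond the scatter) in this assay. Compound 3 is therefore expected at 150 nM, within 40 nM to 600 nM.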

Compound 3, half-maximal inhibitory concentration: 21 nM
The estimate for compound 3 lay 7.1-fold (0.85 log units) above the measured number, outside the stated range (below it).
By their numbers in this assay, from the lowest: compounds 3 and 1 (each within the scatter of the next); then compound 2.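

In this assay, 2-carbamoylazetidin-1-yl in place of 3-carbamoylazetidin-1-yl gives a large step (a 68-fold lower number from compound 2 to compound 3 (1.83 log units; beyond the scatter)) with no change in atoms, so where the carbamoyl group sits on the four-membered ring weighs heavily at this place. Hydrogen in place of chloro on an aromatic carbon gives only a 1.7-fold lower number from compound 1 to compound 3 (0.22 log units; within the scatter), so the chlorine is not required for a number in this range. No available evidence bears on the origin of the large step.

Open, on these data alone, are the opposite configuration at the defined stereocentre and the effect of a carboxylic acid or a primary amine in place of the carbamoyl group.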